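Swapping Nitro for Amino in Two Related Pairs

This account rests on a few compounds, and the source may have more. Where it says the series, first, only, none or still open, it means among the compounds named here.

Four compounds are compared here. Compound 1 `COc1ccc(C(=O)/C=C/c2cc(OC)c(OC)c(OC)c2)cc1[N+](=O)[O-]` and compound 2 `COc1ccc(C(=O)/C=C/c2cc(OC)c(OC)c(OC)c2)cc1N` share one core, while compound 3 `COc1ccc(OC)c(/C=C/C(=O)c2ccc(OC)c([N+](=O)[O-])c2)c1` and the still unmeasured compound 4 `COc1ccc(OC)c(/C=C/C(=O)c2ccc(OC)c(N)c2)c1` share another; how the two cores differ is not broken down here. In a functional assay on B16 cells (Mus musculus) for cytotoxicity, read by MTT assay, with a stated time of 3 days (on this read-out lower numbers stand for stronger inhibition and higher numbers for weaker inhibition), compound 1 gives only a limit, > 100000 nM, a value that is the limit of the assay (the limit of > 100000 nM in this assay, at which 1 of the 3 values shown sits). In this assay compound 2 gives 67000 nM. The change between them, (amino in place of nitro on an aromatic carbon), brought an at least 1.4-fold lower number from compound 1 to compound 2 (0.17 log units; that floor lies within the scatter). In this assay, for the measured compounds named here, compound 3 gives 13000 nM, the lowest of the two numbers so far. Compound 4 carries the same change on its own core, (amino in place of nitro on an aromatic carbon), with the same surroundings around the place. The expected step of a 1.6-fold lower number from compound 3 to compound 4 (0.21 log units; within the scatter) for compound 4 is small and rests on the earlier step of an at least 1.4-fold lower number from compound 1 to compound 2 (0.17 log units; that floor lies within the scatter), which itself sits at a floor within the scatter. In this assay compound 4 is therefore expected to give about 8000 nM, most likely between 2500 nM and 30000 nM.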

Compound 4, half-maximal inhibitory concentration: 5600 nM
The estimate for compound 4 lay 1.4-fold (0.15 log units) above the measured number, within the range that was stated.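

In this assay, amino in place of nitro on an aromatic carbon gave a 2.3-fold lower number from compound 3 to compound 4 (0.37 log units; beyond the scatter), a modest step on the core of compound 3. Both pairs point the same way, but this does not show that the change has the same size on both cores: the same change on two cores in this assay, an at least 1.4-fold lower number (0.17 log units; that floor lies within the scatter) from compound 1 to compound 2 and a 2.3-fold lower number (0.37 log units; beyond the scatter) from compound 3 to compound 4; the limit leaves it open whether they differ Compound 1 gives > 100000 nM, which is a limit of the assay and not a number.

The compounds shown leave open whether another group in the same place, such as a methylamino group or an acetamide, would give a lower number than amino, and whether the step would survive if a hydroxyl group replaced the methoxy group ortho to it. For the compounds shown here, with only two pairs, they also leave open whether amino in place of nitro would give a lower number on any further core.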